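Adding a 2-methylphenyl group to compound 1

The source may report more compounds than this note shows. Statements on the series, on what has been measured and on what is new or still open speak of the compounds shown alone.

Measured so far:
compound 1, `CNC(=O)[C@H]1O[C@@H](n2cnc3c(NC)nc(Cl)nc32)[C@H](O)[C@@H]1O`: 0.282 nM
compound 2, `CNc1nc(Cl)nc2c1ncn2[C@@H]1O[C@H](C(=O)NCC2CC2)[C@@H](O)[C@H]1O`: 1.1 nM
compound 3, `CNc1nc(Cl)nc2c1ncn2[C@@H]1O[C@H](C(=O)N2CCOCC2)[C@@H](O)[C@H]1O`: 3890 nM

In an assay on CHO cells for displacement of a labelled ligand from adenosine receptor A3 (Homo sapiens) (on this read-out higher numbers stand for weaker inhibition and lower numbers for stronger inhibition), compound 1 gives the lowest number of the three, so it is the strongest binder here. Compound 2 comes nearest, with a 3.9-fold higher number from compound 1 to compound 2 (0.59 log units; beyond the scatter); compound 3 lies far off, with a 14000-fold higher number from compound 1 to compound 3 (4.14 log units; beyond the scatter). Between the two larger amides, a 3500-fold higher number from compound 2 to compound 3 (3.55 log units; beyond the scatter).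

Compound 4, `CNC(=O)[C@H]1O[C@@H](n2cnc3c(NCc4ccccc4C)nc(Cl)nc32)[C@H](O)[C@@H]1O`, differs from compound 1 at a different site: 2-methylphenyl in place of hydrogen on a saturated chain carbon bound to a nitrogen on an aromatic ring. Among the measured compounds shown here, both measured steps change the carbonyl side of the shared core, not the nitrogen on the aromatic ring, so no measured step speaks directly to this change. For the measured compounds named here, they show only that compound 1 tolerates a small added group at an amide nitrogen with a modest loss, while a larger change at the carbonyl costs much more. With no direct guide, a small-to-modest weakening is expected, a 3.5-fold higher number from compound 1 to compound 4 (0.55 log units; beyond the scatter). Compound 4 is therefore estimated at 1 nM, within 0.2 nM to 6 nM.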

Compound 4, inhibition constant: 2.19 nM
Compound 4: the middle estimate sits 2.2-fold (0.34 log units) below what was measured, within the range that was stated.
By their numbers in this assay, from the lowest: compound 1; then compounds 2 and 4 (each within the scatter of the next); then compound 3.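

In this assay, among the compounds shown here, the first change at this site, a chain nitrogen on the aromatic ring of the shared core, gives a 7.8-fold higher number from compound 1 to compound 4 (0.89 log units; beyond the scatter), so a 2-methylphenyl group can be added here at a modest cost. That cost is far smaller than the one seen at the carbonyl side, where morpholin-4-yl gives a 14000-fold higher number from compound 1 to compound 3 (4.14 log units; beyond the scatter), although compound 4 gains a whole aromatic ring and still gives 2.19 nM. Nothing available explains why this added ring costs so little.

A plain benzyl group at this site would show how much of the step belongs to the ring and how much to its methyl. A 2-phenylethyl group, with a longer chain, or a pyridine ring in place of the benzene ring would show how far the site's allowance reaches.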